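Trifluoromethyl for fluoro on a fused-ring modulator of metabotropic glutamate receptor 2

This account rests on a few compounds, and the source may have more. Where it says the series, first, only, none or still open, it means among the compounds named here.

Measured so far:
compound 1, `Fc1cc(Cl)ccc1-c1ccc(Cn2nnc3ccccc32)nc1`, 141 nM in a functional assay on cells for positive allosteric modulation of metabotropic glutamate receptor 2 (Homo sapiens), read by fluorescence and calcium flux, with a stated time of 30 min; a higher number here means that more compound is needed for the effect, a lower number that less compound is needed
compound 2, `Fc1cccc2c1nnn2CC1CC1`, 1070 nM in this assay

Among the measured compounds shown here, compound 2 holds the higher of the two numbers so far: in this assay compound 2 gives 1070 nM, while compound 1 gives 141 nM, a gap that lies beyond the scatter of repeated measurements.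

Compound 3, `FC(F)(F)c1cccc2c1nnn2CC1CC1`, has not yet been measured. It differs from compound 2 in one place: trifluoromethyl in place of fluoro on an aromatic carbon, ortho to a fused ring and meta to a fused ring on a six-membered carbon-only aromatic ring of the fused system.

For the measured compounds named here, no measured pair shows this exchange, so no size of step can be read from the data. The expectation is a step from compound 2 to compound 3 of a 1.3-fold lower number from compound 2 to compound 3 (0.13 log units; within the scatter), close to or within the scatter. Compound 3 is therefore estimated at 800 nM in this assay, with a range from 250 nM to 2500 nM.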

Compound 3, half-maximal effective concentration: 148 nM
Compound 3: the middle estimate sits 5.4-fold (0.73 log units) above what was measured; the whole stated range lies above it.
By their numbers in this assay, from the lowest: compounds 1 and 3 (each within the scatter of the next); then compound 2.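

On the aromatic carbon ortho to a fused ring and meta to a fused ring, trifluoromethyl in place of fluoro gives a 7.2-fold lower number from compound 2 to compound 3 (0.86 log units; beyond the scatter) in this assay. Among the compounds shown here, this shows that the number in this assay responds to the group at this position, which the earlier compounds could not show, as they differ in more than one place. No measurement at hand explains why this exchange lowers the number.

The compounds shown leave open whether a chlorine, a methoxy group, a nitrile or a plain hydrogen at this position would give a number like that of fluoro or that of trifluoromethyl. From the compounds shown here alone, it also remains open whether trifluoromethyl at this place would lower the number on the core of compound 1.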